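Aryl ether change on compound 3 in a weak series

This account rests on a few compounds, and the source may have more. Where it says the series, first, only, none or still open, it means among the compounds named here.

Measured so far in an assay on SH-SY5Y cells for inhibition of Voltage-dependent N-type calcium channel subunit alpha-1B (Homo sapiens), read by FLIPR and calcium flux, with stated times of 600 s and 300 s, in the presence of a further agent that is not named here; a higher number here means a weaker inhibitor, a lower number a stronger inhibitor:
compound 1 `N=C(N)NCCCOc1ccc(CNc2nc3ccc(Oc4cccc(C(F)(F)F)c4)cc3s2)cc1` gives 130000 nM
compound 2 `CN(Cc1ccc(OCCCN)cc1)c1nc2ccc(Oc3ccc(F)cc3)cc2s1` gives 98000 nM
compound 3 `CN(C)CCCOc1ccc(CNc2nc3ccc(Oc4cccc(C(F)(F)F)c4)cc3s2)cc1` gives 51000 nM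

Compound 3 has the lowest number of the three. Its nearest neighbour is compound 2, whose value lies within the scatter of that of compound 3, so no order between the two can be read. Compound 1 is further off: a 2.5-fold lower number from compound 1 to compound 3 (0.41 log units; beyond the scatter). That step concerns the saturated chain at one end of the molecule, not the aryl ether.

Compound 4 `CN(C)CCCOc1ccc(CNc2nc3ccc(Oc4ccc(C#N)cc4)cc3s2)cc1` is the next member. It differs from compound 3 in one place: 4-cyanophenyl in place of 3-(trifluoromethyl)phenyl on an oxygen on an aromatic ring. Within the data shown here, no measured step touches this position. Compounds 2 and 3 differ in more than one place, and their two values show only that they lie within the scatter of each other; nothing about the aryl ether alone can be taken from them. The step from compound 1 to compound 3 is the only measured one, and it sits elsewhere in the structure.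

With nothing bearing directly on the change, compound 4 is expected to show no step beyond the scatter, a 1.4-fold higher number from compound 3 to compound 4 (0.14 log units; within the scatter). The estimate for compound 4 in this assay is 70000 nM, with an expected range from 25000 nM to 200000 nM. The range is wide: the series is weak throughout, compound 1 giving 130000 nM and compound 3 giving 51000 nM.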

Compound 4, half-maximal inhibitory concentration: 105000 nM
Compound 4: middle estimate off by 1.5-fold (0.18 log units), on the low side, within the range that was stated.
By their numbers in this assay, from the lowest: compounds 3, 2, 4 and 1 (each within the scatter of the next, the first and the last beyond it).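

Among these compounds, the aryl ether position responds in this assay: 4-cyanophenyl in place of 3-(trifluoromethyl)phenyl gives a 2.1-fold higher number from compound 3 to compound 4 (0.31 log units; beyond the scatter), the first measured step at this position and a modest one, though beyond the scatter. The change leaves the series weak, with compound 4 at 105000 nM, and it alters both the substituent and its place on the ring, as the two group names show, so this single step cannot assign the shift to either alteration. No measurement among those available accounts for the step.

Still open, from the compounds shown here alone, is how much of the step belongs to the nitrile and how much to the trifluoromethyl group, and whether an unsubstituted phenyl or a methoxy-bearing phenyl on the same oxygen would fall nearer compound 3 or compound 4. Going by these compounds, this change has also been read on only one side chain, that of compound 3 and compound 4, so whether it gives a step of similar size with another group at the end of the chain, such as a carboxylic acid, remains unknown.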